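The compounds below may be only part of what the source reports. "The series", "measured", "known", "first", "only" and "open" are said of these compounds alone.

Measured so far:

Compound 1, `CC(=O)CC/C=C(\C)CCC1=C(C)CCCC1(C)C`: in a functional assay on 786-0 cells (Homo sapiens) for inhibition (a higher number here means a weaker inhibitor of growth, a lower number a stronger inhibitor of growth), compound 1 gives > 15000 nM, which is a limit of the assay and not a number.
Compound 2, `C=C1CCCC(C)(C)C1CC[C@]1(C)CC[C@@H]([C@@H](C)C(=O)O)OO1`: in this assay compound 2 gives > 10000 nM, again only a limit.
Compound 3, `C=C1CCCC(C)(C)C1(O)CC/C(C)=C/CC[C@]1(C)CC[C@@H]([C@@H](C)C(=O)OC)OO1`: in this assay compound 3 gives > 17500 nM, also a limit.

Where compound 2 stands: only a limit is known for it, and the two further values in the series are limits as well, so no ordering of the three compounds can be read from this assay. The three limits sit at different heights: the limit of > 10000 nM in this assay, at which 1 of the 3 values shown sits, (the limit of > 15000 nM in this assay, at which 1 of the 3 values shown sits), (the limit of > 17500 nM in this assay, at which 1 of the 3 values shown sits). Among the compounds with values here, none of these gives a number to compare against, and no step between measured compounds can be counted.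

Compound 4, `C=C1CCCC(C)(C)C1CC[C@@]1(C)CC[C@H]([C@@H](C)C(=O)O)OO1`, has yet to be measured in this assay. It differs from compound 2 as follows: the two compounds have the same atoms and bonds; at least one stereo element is drawn with a configuration in one of them and without one in the other: 2 of 4 stereo elements differ; a stereocentre at a saturated ring carbon is drawn R in compound 2 and S in compound 4; a stereocentre at a saturated ring carbon is drawn S in compound 2 and R in compound 4.

With compound 2 known only as a limit, the step is expected to be none beyond the scatter, so the estimated step from compound 2 to compound 4 is a step that the limit leaves unreadable from compound 2 to compound 4. Compound 4 is thus expected to give about 15000 nM in this assay, within a range of 5000 nM to 40000 nM, most likely reported once more as a limit.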

Compound 4, concentration for 50% growth inhibition: 940 nM
Beside the measured number, compound 4's estimate is 16-fold (1.20 log units) above it; the measured number lies below the stated range.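

In this assay the series now has its first measured number and its first readable step: with atoms and bonds the same, the change of the two saturated ring stereocentres gives an at least 10-fold lower number from compound 2 to compound 4 (1.02 log units; beyond the scatter). Within this pair, the drawn configuration at these two ring carbons therefore separates a compound with a measurable growth-inhibition value from one known only as a limit, while the other two stereo elements stay the same. The step has a limit at one end, so its size is a lower bound: the limit of > 10000 nM in this assay, at which 1 of the 4 values shown sits.

Steps involving compound 1 and compound 3 cannot be read, as both remain limits and neither differs from another compound shown in only one place. The compounds shown do not tell whether one ring stereocentre alone accounts for the step or both are needed, nor whether a primary amide or a hydroxymethyl group in place of the carboxylic acid would keep the growth inhibition of compound 4.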